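The source may hold more compounds than are shown below. What is called first, only, known or untested is meant among the compounds shown, and "the series" means these compounds.

Of the compounds shown here, two have been measured in an assay on isolated protein for inhibition of activin receptor type-2A (Homo sapiens), read by 33P incorporation, with a stated time of 20 min, in the presence of a further agent that is not named here; a lower number here means a stronger inhibitor, a higher number a weaker inhibitor. Compound 1, `CNc1nc2c(-c3ccnc(OC)c3)cnn2cc1C`, gives 1300 nM in this assay. Compound 2, `CCc1nc2c(-c3ccnc(OC)c3)cnn2cc1OC`, gives 960 nM in this assay, a number so close to that of compound 1 that the two cannot be told apart, and so compound 2 cannot be called the stronger of the pair.

Compound 3, `COc1cc(-c2cnn3cc(OC)c(C4CCOC4)nc23)ccn1`, has not yet been measured. It differs from compound 2 in one place: oxolan-3-yl in place of ethyl on an aromatic carbon. Among the measured compounds shown here, no measured pair shows what this kind of change does, so nothing in the data points to a direction. A step from compound 2 to compound 3 that is expected to stay within the scatter, a 1.2-fold lower number from compound 2 to compound 3 (0.08 log units; within the scatter), is therefore the plainest reading. On that basis compound 3 is estimated to give 800 nM in this assay, with a range from 300 nM to 2500 nM.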

Compound 3, half-maximal inhibitory concentration: 1900 nM
Compound 3: the middle estimate sits 2.4-fold (0.38 log units) below what was measured; measured number inside the range.
By their numbers in this assay, from the lowest: compounds 2, 1 and 3 (each within the scatter of the next).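

In this assay, placing oxolan-3-yl in place of ethyl on this aromatic carbon gives a 2.0-fold higher number from compound 2 to compound 3 (0.30 log units; within the scatter), so compound 2 and compound 3 cannot be told apart. Among the compounds shown here, this is the first reading of a change at this position, and it shows that a group of 5 heavy atoms, with a five-membered non-aromatic ring and a hydrogen-bond acceptor, can stand here in place of one of 2 heavy atoms without a change that exceeds the scatter. Nothing measured here offers an explanation for this reading.

A single step cannot show how far this tolerance extends, or whether the ring oxygen matters, which a cyclopentyl group at the same carbon could test. From the compounds shown here alone, whether a different kind of group here, such as an amine, a carboxylic acid or a longer chain, would leave the number unchanged also remains open.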